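A few compounds are considered here, and "the series" means these few. Any claim that something is new, unique, unknown or untested is made for them only; others in the source may bear on it.

For the measured compounds named here, compound 2 `CC[C@](C)(O)CC(=O)O[C@H](CC=C(C)C)C1=CC(=O)c2c(O)ccc(O)c2C1=O` gives the lowest of the three numbers so far in a functional assay on DU-145 cells (Homo sapiens) for cytotoxicity, read by MTT assay (a lower number here means a stronger inhibitor, a higher number a weaker inhibitor), at 20500 nM; compound 1 `COCCO[C@H](CC=C(C)C)C1=CC(=O)c2c(O)ccc(O)c2C1=O` gives 43200 nM and compound 3 `CC(C)=CC[C@@H](OC(=O)C1CCOC1)C1=CC(=O)c2c(O)ccc(O)c2C1=O` gives 47500 nM. Compound 4 `CC(C)=CC[C@@H](OC(=O)C1CCCOC1)C1=CC(=O)c2c(O)ccc(O)c2C1=O` is reached from compound 2 by oxan-3-yl in place of 2-hydroxy-2-methylbutyl on a carbonyl carbon. Going by the values given here, two measured steps bear on this exchange: the ester chain entering on compound 2 gave a 2.1-fold lower number from compound 1 to compound 2 (0.32 log units; beyond the scatter), while putting oxolan-3-yl in place of 2-hydroxy-2-methylbutyl on the carbonyl carbon gave a 2.3-fold higher number from compound 2 to compound 3 (0.36 log units; beyond the scatter); the parallel exchange of 2-methoxyethyl for (oxolan-3-yl)carbonyl gave a 1.1-fold higher number from compound 1 to compound 3 (0.04 log units; within the scatter). Compound 4 differs from compound 3 only in the size of the ring that enters, so for compound 4 a step of the same kind in this assay is expected, a 2.2-fold higher number from compound 2 to compound 4 (0.34 log units; beyond the scatter). Compound 4 is therefore estimated at 45000 nM, within 24000 nM to 85000 nM.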

Compound 4, half-maximal inhibitory concentration: 29700 nM
The estimate for compound 4 lay 1.5-fold (0.18 log units) above the measured number; low and high end bracket the measured number.
By their numbers in this assay, from the lowest: compounds 2, 4, 1 and 3 (each within the scatter of the next, the first and the last beyond it).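

In this assay, the oxan-3-yl ring on the carbonyl carbon takes the place of the open 2-hydroxy-2-methylbutyl chain, with its hydrogen-bond donor and defined stereocentre, in a step that stays within the scatter (a 1.4-fold higher number from compound 2 to compound 4 (0.16 log units; within the scatter)). Enlarging the ring from oxolan-3-yl also stays within the scatter (a 1.6-fold lower number from compound 3 to compound 4 (0.20 log units; within the scatter)), as does the change from the 2-methoxyethyl ether (a 1.5-fold lower number from compound 1 to compound 4 (0.16 log units; within the scatter)). Nothing available explains these steps. Open, going by these compounds, is whether the ring oxygen matters, which a cyclohexyl ring would test. Also open, on these data alone, is whether a piperidin-3-yl amine or a carboxylic acid at this place would give a step beyond the scatter.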